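Phenoxy replacing pyrrolidinyl on the shared core

The source may report more compounds than this note shows. Statements on the series, on what has been measured and on what is new or still open speak of the compounds shown alone.

Of the compounds shown here, three have been measured in an assay for inhibition of acid-sensing ion channel 3 (Homo sapiens), read by patch clamp, tested at 1 uM; on this read-out lower numbers stand for less inhibition and higher numbers for more inhibition at the one concentration tested (going by the name of the read-out). Compound 1 `NC(N)=NC(=O)c1nc(Cl)c(NCc2ccc3ccccc3c2)nc1N` gives 27%. Compound 2 `NC(N)=NC(=O)c1nc(Cl)c(N2CCCC2)nc1N` gives 12%, the lowest of the three numbers, standing beyond the scatter below compound 1 and further still below compound 3. Compound 3 `NC(N)=NC(=O)c1nc(Cl)c(Nc2ccc3ncccc3c2)nc1N` gives 41%, the highest of the three numbers. No pair among these three differs in a single place, so no step between measured compounds can be stated; the two compounds carrying an aromatic group at the varied position show the higher numbers, the pyrrolidinyl compound the lowest.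

Compound 4 `NC(N)=NC(=O)c1nc(Cl)c(Oc2ccccc2)nc1N` has not yet been measured in this assay. It differs from compound 2 as follows: phenoxy in place of pyrrolidin-1-yl on an aromatic carbon. An aromatic group enters at the position where compound 1 and compound 3 carry theirs, so the step is expected to be a number 14 percentage points higher from compound 2 to compound 4 (beyond the scatter). Compound 4 is estimated at 26%, with a range from 10% to 45%.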

Compound 4, a percentage reported as inhibition, at one concentration (the size of the read-out at that concentration, not a potency): 23%
Compound 4: the middle estimate sits 3 percentage points above what was measured; the range from low to high includes it.
By their numbers in this assay, from the lowest: compound 2; then compounds 4 and 1 (each within the scatter of the next); then compound 3.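

Within the data shown here, this is the first step at this position that can be read in one place: on the aromatic carbon next to the ring nitrogen and ortho to a chloro group, in this assay, phenoxy in place of pyrrolidin-1-yl gives a number 11 percentage points higher from compound 2 to compound 4 (beyond the scatter). The read-out therefore responds to the group at this position, although the change is modest and the hydrogen-bond donor and acceptor counts and the net charge are the same for both groups. The swap changes the ring and the linking atom together, and nothing available explains the step.

On these data alone, whether the step follows the aromatic ring or the oxygen link remains open. Cyclopentyloxy, which keeps the oxygen on a non-aromatic ring, and phenylamino, which keeps the aromatic ring on a nitrogen, would separate the two.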